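Methyl on the Indole Nitrogen: What to Expect for Growth Inhibition

The source may hold more compounds than are shown below. What is called first, only, known or untested is meant among the compounds shown, and "the series" means these compounds.

Measured so far in a functional assay on KB cells (Homo sapiens) for inhibition, read by sulforhodamine B assay, with a stated time of 72 h; on this read-out higher numbers stand for weaker inhibition of growth and lower numbers for stronger inhibition of growth:
compound 1, `CCOC(=O)/C=C/c1ccncc1-c1ccc2[nH]ccc2c1`, gives > 10000 nM
compound 2, `O=C(O)/C=C/c1ccncc1-c1ccc2cc[nH]c2c1`, gives > 10000 nM
compound 3, `NC(=O)/C=C/c1ccncc1-c1ccc2ccccc2c1`, gives > 10000 nM.

For compound 1 the value > 10000 nM is a limit of the assay, not a number. The same holds for compound 2, whose > 10000 nM is a limit. Compound 3 also returns only a limit, > 10000 nM. Compound 1 therefore stands nowhere in particular on the numbers shown: all three results sit at the limit of > 10000 nM in this assay, at which 3 of the 3 values shown sit, so no compound can be ordered against another, and no measured step exists from which a trend could be read.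

Compound 4, `CCOC(=O)/C=C/c1ccncc1-c1ccc2c(ccn2C)c1`, differs from compound 1 in one place: methyl in place of hydrogen on an aromatic nitrogen. For the measured compounds named here, the only related information is that compound 1 and its two companions all stayed at the limit, which leaves the direction of this change open. With nothing pointing to a gain in growth inhibition, the step from compound 1 to compound 4 in this assay is expected to be none beyond the scatter, most likely another limit, so a step that the limit leaves unreadable from compound 1 to compound 4 is the expected outcome. For compound 4 the estimate in this assay is 20000 nM, within a range from 8000 nM to 60000 nM.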

Compound 4, concentration for 50% growth inhibition: 6250 nM
Compound 4: the middle estimate sits 3.2-fold (0.51 log units) above what was measured; measured number below the stated range.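

In this assay, methyl in place of hydrogen on the aromatic nitrogen yields the first result in this set that is a real number rather than a limit, and the change reads as an at least 1.6-fold lower number from compound 1 to compound 4 (0.20 log units; that floor lies within the scatter). That figure is only a floor and not the size of the change, so the true shift may be small or much larger, and the floor alone does not show a gain beyond the scatter. Still, compound 4 shows that a compound with this methyl can give a readable value, something the earlier compounds could not show: the limit of > 10000 nM in this assay, at which 3 of the 4 values shown sit.

On these data alone, it remains open whether a larger group on the same nitrogen, such as an ethyl or a benzyl group, would move the number further, or whether the value would stay much the same. Also open, as far as these compounds go, is whether this methyl would give a readable value with a carboxylic acid or an amide in place of the ethyl ester of compound 4, which would show whether the result depends on the ester.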